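The source may report more compounds than this note shows. Statements on the series, on what has been measured and on what is new or still open speak of the compounds shown alone.

Values in an ADME assay on NHDF cells (Homo sapiens) for cytotoxicity, read by MTT assay, with a stated time of 72 h; a lower number here means a stronger inhibitor, a higher number a weaker inhibitor
- compound 1 `COc1ccc(/C=C2\CCC/C(=C\c3ccc(Br)cc3)C2=O)cc1OC` gives 13100 nM
- compound 2 `COc1ccc(/C=C2\CCC/C(=C\c3ccc(Cl)c(Cl)c3)C2=O)cc1OC` gives 10100 nM
- compound 3 `COc1ccc(/C=C2\CCC/C(=C\c3ccc(O)c(Cl)c3)C2=O)cc1OC` is not yet measured

Compound 2 lies within the scatter of compound 1 (see a 1.3-fold lower number from compound 1 to compound 2 (0.11 log units; within the scatter)) and the two cannot be ranked. Compound 3 departs from compound 2 by hydroxy in place of chloro on an aromatic carbon, which turns 3,4-dichlorophenyl into 3-chloro-4-hydroxyphenyl. Going by the values given here, no measured compound carries a hydroxy, so the one measured step bears only loosely on this change. On that step alone, no shift beyond the scatter is expected in this assay and no direction is indicated. The estimated step is a 1.1-fold lower number from compound 2 to compound 3 (0.05 log units; within the scatter) and it has little direct support. Compound 3 is estimated at 9000 nM (range 3500 nM to 25000 nM).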

Compound 3, half-maximal inhibitory concentration: 21900 nM
The estimate for compound 3 lay 2.4-fold (0.39 log units) below the measured number; low and high end bracket the measured number.
By their numbers in this assay, from the lowest: compounds 2, 1 and 3 (each within the scatter of the next, the first and the last beyond it).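

In this assay, going by these compounds alone, hydroxy in place of chloro on the aromatic carbon para to a large group gives the only step in this short series that lies beyond the scatter: a 2.2-fold higher number from compound 2 to compound 3 (0.34 log units; beyond the scatter), a modest shift showing that this position does not accept every exchange without change in the number. Against the 4-bromophenyl compound, the 3-chloro-4-hydroxyphenyl group does not separate: a 1.7-fold higher number from compound 1 to compound 3 (0.22 log units; within the scatter). No measured evidence is at hand to explain the step.

On these data alone, whether the shift follows from the entering hydroxy or from the loss of chloro stays open, as does what an amine or a carboxylic acid would do at this position. As far as these compounds go, the hydroxy reading rests on compound 3 alone, and its outcome without the ortho chloro group is unknown.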